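The source may report more compounds than this note shows. Statements on the series, on what has been measured and on what is new or still open speak of the compounds shown alone.

Going by the values given here, compound 1 `COc1ccc(-c2cc(/C=C/C(=O)c3ccc(N)cc3)[nH]n2)cc1` is one of three compounds measured in a functional assay on Malme-3M cells (Homo sapiens) for inhibition, read by sulforhodamine B assay, with a stated time of 48 h; on this read-out lower numbers stand for stronger inhibition of growth and higher numbers for weaker inhibition of growth. In this assay compound 1 gives 2180 nM. The other two are compound 2 `COc1cc(-c2cc(/C=C/C(=O)c3ccc(Cl)c(Cl)c3)[nH]n2)cc(OC)c1OC`, which in this assay gives 29200 nM, and compound 3 `COc1ccc(C(=O)/C=C/c2cc(-c3cc(OC)c(OC)c(OC)c3)n[nH]2)cc1`, which in this assay gives 1860 nM. Compound 1 therefore holds the second highest of the three numbers: its value and that of compound 3 lie within the usual scatter of each other, whereas compound 2 lies beyond the scatter on the higher side. Among the compounds with values here, the one single-point change among the measured compounds is the step of a 16-fold lower number from compound 2 to compound 3 (1.20 log units; beyond the scatter), which concerns the ring on the carbonyl carbon.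

Compound 4 `COc1ccc(-c2cc(/C=C/C(=O)c3ccc(N)cc3)[nH]n2)cc1OC` differs from compound 1 by methoxy in place of hydrogen on an aromatic carbon, a methoxy in place of hydrogen on an aromatic carbon, ortho to a methoxy group and meta to a large group. Within the data shown here, no measured step touches this ring directly; compound 2 and compound 3 carry three methoxy groups there, but they differ from compound 1 in more than one place, and compound 3 and compound 1 give values within the scatter. Compound 4 is therefore expected to give 2000 nM. The expected range for compound 4 runs from 800 nM to 5000 nM. This would mean an expected step of a 1.1-fold lower number from compound 1 to compound 4 (0.04 log units; within the scatter), not beyond the scatter.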

Compound 4, concentration for 50% growth inhibition: 6720 nM
Compound 4: middle estimate off by 3.4-fold (0.53 log units), on the low side; the measured number lies above the stated range.
By their numbers in this assay, from the lowest: compounds 3 and 1 (each within the scatter of the next); then compound 4; then compound 2.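

In this assay, going by these compounds alone, the step of a 3.1-fold higher number from compound 1 to compound 4 (0.49 log units; beyond the scatter) gives the first direct reading of this position: a methoxy in place of hydrogen on an aromatic carbon, ortho to a methoxy group and meta to a large group, weakens growth inhibition modestly, but by more than the usual scatter. The earlier compounds shown here could not show this, since compound 2 and compound 3 also carry methoxy groups on this ring but differ from compound 1 in more than one place, so their values say nothing about this single change. No measurement at hand explains why the added methoxy has this effect.

The compounds shown leave open whether the weaker inhibition belongs to methoxy in particular or would also come with another group at this position, such as fluorine, hydroxy or ethoxy. They also leave open whether the same change would have a step of similar size and direction when the ring on the carbonyl carbon is different, or when a further methoxy is added to the same ring.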